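A few compounds are considered here, and "the series" means these few. Any claim that something is new, unique, unknown or untested is made for them only; others in the source may bear on it.

Compounds measured in a functional assay on MCF7 cells (Homo sapiens) for cytotoxicity, read by MTT assay, with a stated time of 48 h; a higher number here means a weaker inhibitor, a lower number a stronger inhibitor:

- compound 1, `COc1cc(-c2nnc3n2NC(c2ccco2)C(C(=O)c2ccc(Br)cc2)S3)cc(OC)c1OC`: > 100000 nM, a limit of the assay, not a number.
- compound 2, `COc1cc(-c2nnc3n2NC(c2ccco2)C(C(=O)c2ccc(Cl)cc2)S3)cc(OC)c1OC`: > 100000 nM, again a limit of the assay.
- compound 3, `COc1ccc(C(=O)C2Sc3nnc(-c4cc(OC)c(OC)c(OC)c4)n3NC2c2cccs2)cc1`: 49500 nM.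

In this assay compound 2 stands at a limit, and the step that the two limits leave unreadable from compound 1 to compound 2 cannot be read because both values sit at the limit of > 100000 nM in this assay, at which 2 of the 3 values shown sit. Compound 4, `COc1cc(-c2nnc3n2NC(c2ccco2)C(C(=O)c2ccc(C)cc2)S3)cc(OC)c1OC`, is not yet measured; it differs from compound 2 by methyl in place of chloro on an aromatic carbon. For the measured compounds named here, no measured step tells how this exchange changes potency, so no direction can be drawn from the data. Compound 2 is weak in this assay, and compound 4 is expected to stay near that limit, with the step that the limit leaves unreadable from compound 2 to compound 4 within the usual scatter. The estimate for compound 4 is 120000 nM, between 40000 nM and 400000 nM.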

Compound 4, half-maximal inhibitory concentration: > 100000 nM
Compound 4 gave a limit, no number; the forecaster's own chance of this, stated with the estimate: 60%; the middle value is on the limit's open side.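

No new step can be read among compound 1, compound 2 and compound 4, as each gives only a limit, not a number: the limit of > 100000 nM in this assay, at which 3 of the 4 values shown sit.

The compounds shown leave open how bromo, chloro and methyl compare in this assay.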